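This account rests on a few compounds, and the source may have more. Where it says the series, first, only, none or still open, it means among the compounds named here.

In a functional assay on HL-60 cells (Homo sapiens) for inhibition, read by MTT assay, with a stated time of 72 h (on this read-out higher numbers stand for weaker inhibition and lower numbers for stronger inhibition), compound 1 `Cc1nc(-c2cccc(F)c2)c(C(=O)N2CCN(c3cccc(Cl)c3)CC2)o1` gives 33.7 nM and compound 3 `COc1cc(-c2nc(C)oc2C(=O)N2CCN(c3cccc(Cl)c3)CC2)ccc1O` gives 85.9 nM, the higher of the two numbers. Compound 2 `COc1ccc(-c2nc(C)oc2C(=O)N2CCN(c3cccc(Cl)c3)CC2)cc1` is reported as "not active" (no number reported), with no number to compare. Among the compounds with values here, the only measured step is a 2.5-fold higher number from compound 1 to compound 3 (0.41 log units; beyond the scatter), modest but beyond the scatter. Compound 4 `Cc1nc(-c2cccc(O)c2)c(C(=O)N2CCN(c3cccc(Cl)c3)CC2)o1` differs from compound 3 by 3-hydroxyphenyl in place of 4-hydroxy-3-methoxyphenyl on an aromatic carbon, with 3-hydroxyphenyl in place of 4-hydroxy-3-methoxyphenyl. The entering group is closer by name to the 3-fluorophenyl of compound 1, at 33.7 nM, so a small move toward lower numbers is expected, though compound 2 counsels caution. The estimated step is a 1.7-fold lower number from compound 3 to compound 4 (0.24 log units; within the scatter). Compound 4 is estimated at 50 nM, within an expected range of 15 nM to 200 nM.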

Compound 4, half-maximal inhibitory concentration: 105 nM
Beside the measured number, compound 4's estimate is 2.1-fold (0.32 log units) below it, and the stated range covers the measured number.
By their numbers in this assay, from the lowest: compound 1; then compounds 3 and 4 (each within the scatter of the next).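

In this assay, on the aromatic carbon next to the ring nitrogen, 3-hydroxyphenyl and 4-hydroxy-3-methoxyphenyl cannot be told apart, with a 1.2-fold higher number from compound 3 to compound 4 (0.09 log units; within the scatter). Hydroxy in place of fluoro gives a 3.1-fold higher number from compound 1 to compound 4 (0.49 log units; beyond the scatter), so the 3-fluorophenyl of compound 1 keeps the lowest number of the three. Nothing available explains either step.

From the compounds shown here alone, it remains open whether an amino group or a carboxylic acid in place of that fluoro would hold the number of compound 1. Also open, going by these compounds, is what separates compound 2, reported as not active, from compound 3.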